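This account rests on a few compounds, and the source may have more. Where it says the series, first, only, none or still open, it means among the compounds named here.

Within the data shown here, in a functional assay on HCT-15 cells (Homo sapiens) for antiproliferative activity, read by sulforhodamine B assay, with a stated time of 72 h (a lower number here means a stronger inhibitor, a higher number a weaker inhibitor), compound 1 `COc1cc(/C=C/COC(C)=O)ccc1OC(C)=O` gives 3260 nM, the lowest of the three numbers so far. Compound 2 `CCC(=O)OC/C=C/c1ccc(OC(=O)CC)c(OC)c1` gives 29600 nM and compound 3 `COc1cc(/C=C/COC(=O)C(C)C)ccc1OC(=O)C(C)C` gives 34600 nM, both higher beyond the scatter. Compound 4 `CCCC(=O)Oc1ccc(/C=C/COC(C)=O)cc1OC` differs from compound 1 at a single ester: ethyl in place of hydrogen on a saturated chain carbon bound to a carbonyl carbon, which turns one acetoxy into (propylcarbonyl)oxy. The ester groups of compound 2 and compound 3 both differ from those of compound 1, and both of those compounds are weaker. With only one ester changed here, a rise of moderate size is expected, estimated as a 3.1-fold higher number from compound 1 to compound 4 (0.49 log units; beyond the scatter). Compound 4 is therefore estimated at 10000 nM, within a range of 3000 nM to 35000 nM.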

Compound 4, half-maximal inhibitory concentration: 17100 nM
Beside the measured number, compound 4's estimate is 1.7-fold (0.23 log units) below it; the measured number falls inside the stated range.
By their numbers in this assay, from the lowest: compound 1; then compounds 4, 2 and 3 (each within the scatter of the next, the first and the last beyond it).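

Among these compounds, compound 4 gives the first comparison in this assay in which only one ester changes, while the other stays acetoxy. Ethyl in place of hydrogen on a saturated chain carbon bound to a carbonyl carbon gives a 5.2-fold higher number from compound 1 to compound 4 (0.72 log units; beyond the scatter), so this single change moves the number beyond the scatter. Nothing available explains this rise.

As far as these compounds go, whether a longer chain, a benzoyl group or an amine at this place would move the number the same way remains open. So does the effect of the same change at the other ester.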